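Methoxy placement on the fused ring of the core

A few compounds are considered here, and "the series" means these few. Any claim that something is new, unique, unknown or untested is made for them only; others in the source may bear on it.

For the measured compounds named here, compound 1 `COc1nn2cc(-c3cc4ccccc4o3)nc2s1` sets the lowest number so far in a functional assay on HEK293 cells for antagonist activity at proteinase-activated receptor 4 (Homo sapiens), read by FLIPR and calcium flux, with a stated time of 30 min (a higher number here means a weaker inhibitor, a lower number a stronger inhibitor), where compound 1 gives 4 nM. The nearest neighbour is compound 2 `COc1nn2cc(-c3cc4c(OC)cccc4o3)nc2s1`, which in this assay gives 7.6 nM; the step of a 1.9-fold higher number from compound 1 to compound 2 (0.28 log units; within the scatter). The furthest is compound 3 `Cc1nn2cc(-c3cc4ccccc4o3)nc2s1`, which in this assay gives 37 nM; the step of a 9.3-fold higher number from compound 1 to compound 3 (0.97 log units; beyond the scatter).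

Compound 4 `COc1nn2cc(-c3cc4cccc(OC)c4o3)nc2s1` has not been measured. Relative to compound 1 it carries methoxy in place of hydrogen on an aromatic carbon. The change is again a methoxy in place of hydrogen on the six-membered carbon ring of the fused system, as in the step from compound 1 to compound 2, only at a different carbon, one that is ortho to a fused ring. That step, a 1.9-fold higher number from compound 1 to compound 2 (0.28 log units; within the scatter), is the only one that bears directly on the question; the step of a 9.3-fold higher number from compound 1 to compound 3 (0.97 log units; beyond the scatter) concerns the other end of the core and says nothing about this ring. Going by the values given here, on the one relevant comparison, no change beyond the scatter is expected in this assay, with a slight lean towards a higher number. For compound 4 the estimate is 7 nM, range 3 nM to 20 nM. The expected step is thus a 1.8-fold higher number from compound 1 to compound 4 (0.24 log units; within the scatter).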

Compound 4, half-maximal inhibitory concentration: 2.8 nM
The estimate for compound 4 lay 2.5-fold (0.40 log units) above the measured number; measured number below the stated range.
By their numbers in this assay, from the lowest: compounds 4, 1 and 2 (each within the scatter of the next, the first and the last beyond it); then compound 3.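

In this assay the methoxy in place of hydrogen on this aromatic carbon, ortho to a fused ring and meta to a fused ring, is accepted on the core of compound 1 with no change that can be told from the scatter (a 1.4-fold lower number from compound 1 to compound 4 (0.15 log units; within the scatter)). The earlier methoxy step at a different carbon of the same six-membered aromatic ring also stays within the scatter (a 1.9-fold higher number from compound 1 to compound 2 (0.28 log units; within the scatter)), so two carbons of this ring now carry the group without a step beyond the scatter, and the low-nanomolar numbers of compound 1 hold at both. Nothing available on these compounds accounts for this tolerance at either carbon.

Still open, from the compounds shown here alone, is whether the tolerance at this carbon extends to a longer chain such as butoxy, to an amine or to a carboxylic acid in place of the methoxy. Also open, going by these compounds, is whether the larger step at the other end of the core (a 9.3-fold higher number from compound 1 to compound 3 (0.97 log units; beyond the scatter)) would keep its size with a methoxy on this carbon.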